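Swapping one ring for another on compound 3

The source may report more compounds than this note shows. Statements on the series, on what has been measured and on what is new or still open speak of the compounds shown alone.

- compound 1 `CC(=O)c1ncc([C@@H](O)[C@H](O)[C@H](O)CO)s1`: 668 ng.h/mL
- compound 2 `CC(O)c1nc([C@@H](O)[C@H](O)[C@H](O)CO)c[nH]1`: 10300 ng.h/mL
- compound 3 `Cc1nc(-c2nc([C@@H](O)[C@H](O)[C@H](O)CO)c[nH]2)cs1`: 1970 ng.h/mL

In an ADME assay on the whole organism (plasma, strain 129/SvEvBrd x C57BL/6) for pharmacokinetics, with Mus musculus as the target, at a dose of 10 mg/kg by the oral route (on this read-out lower numbers stand for lower exposure and higher numbers for higher exposure at the dose given), compound 3 stands in the middle of the three, higher than compound 1 and lower than compound 2. Compound 4 `OC[C@@H](O)[C@@H](O)[C@H](O)c1c[nH]c(-c2cocn2)n1` carries 1,3-oxazol-4-yl in place of 2-methyl-1,3-thiazol-4-yl on an aromatic carbon. For the measured compounds named here, one measured step touches this place: a 5.2-fold lower number from compound 2 to compound 3 (0.72 log units; beyond the scatter), which is modest but beyond the scatter. That step replaced 1-hydroxyethyl with a ring, whereas here one five-membered aromatic ring replaces another, so a smaller step seems likely. The expected change is a 1.2-fold higher number from compound 3 to compound 4 (0.09 log units; within the scatter), which would not clearly exceed the scatter. The estimate for compound 4 is 2400 ng.h/mL, with an expected range from 800 ng.h/mL to 7500 ng.h/mL.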

Compound 4, area under the concentration-time curve: 868 ng.h/mL
The estimate for compound 4 lay 2.8-fold (0.44 log units) above the measured number, within the range that was stated.
By their numbers in this assay, from the lowest: compounds 1 and 4 (each within the scatter of the next); then compound 3; then compound 2.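

In this assay, exchanging one five-membered aromatic ring for another is not a neutral change: the swap gives a 2.3-fold lower number from compound 3 to compound 4 (0.36 log units; beyond the scatter), even though the two rings have the same counts of hydrogen-bond donors and acceptors. Against 1-hydroxyethyl, 1,3-oxazol-4-yl gives a 12-fold lower number from compound 2 to compound 4 (1.07 log units; beyond the scatter), so both rings at this place stand lower than that open group. Nothing available explains these differences. On these data alone, it remains open whether an amine, a carboxylic acid or a longer chain at this place would bring the number back towards that of compound 2.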